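Compound 4: 3-hydroxyphenyl replacing the 4-chlorophenyl of compound 2

The compounds below may be only part of what the source reports. "The series", "measured", "known", "first", "only" and "open" are said of these compounds alone.

Among the compounds with values here, in a functional assay on T47D cells (Homo sapiens) for inhibition, read by CCK-8 assay, with a stated time of 72 h, tested at 10 uM (a lower number here means less inhibition of growth, a higher number more inhibition of growth at the concentration tested), compound 2 (`CN(C)C(=O)c1cc2cnc(Nc3ccc(NC(=O)C4(C(=O)Nc5ccc(Cl)cc5)CC4)cc3)nc2n1C1CCCC1`) gives 95% and stands highest of the three numbers so far, above compound 1 (`CN(C)C(=O)c1cc2cnc(Nc3ccc(N)cn3)nc2n1C1CCCC1`) at 61.1% and compound 3 (`CN(C)C(=O)c1cc2cnc(Nc3ccc(NC(=O)C4(C(=O)Nc5cccc(F)c5)CC4)cc3)nc2n1C1CCCC1`) at -0.4% in the same read-out. Compound 4 (`CN(C)C(=O)c1cc2cnc(Nc3ccc(NC(=O)C4(C(=O)Nc5cccc(O)c5)CC4)cc3)nc2n1C1CCCC1`) has 3-hydroxyphenyl in place of 4-chlorophenyl on an amide-type nitrogen. Within the data shown here, the one measured step at that place is large, a number 95.4 percentage points lower from compound 2 to compound 3 (beyond the scatter) for 3-fluorophenyl in place of 4-chlorophenyl. Among the measured compounds shown here, no measured compound carries 3-hydroxyphenyl, so the size stays uncertain. The expected change in this assay is a large fall, estimated as a number 70 percentage points lower from compound 2 to compound 4 (beyond the scatter) with wide uncertainty. Compound 4 is expected at 25% (estimated range -5% to 75%).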

Compound 4, percent growth inhibition at one concentration: 83.7%
Compound 4: the middle estimate sits 58.7 percentage points below what was measured; the measured number lies above the stated range.
By their numbers in this assay, from the lowest: compound 3; then compound 1; then compound 4; then compound 2.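

In this assay, leaving 4-chlorophenyl on this amide-type nitrogen does not by itself cost the growth inhibition: 3-hydroxyphenyl gives a number 11.3 percentage points lower from compound 2 to compound 4 (beyond the scatter) as a modest step only. The outcome turns on the group on the aromatic carbon, with hydroxy in place of fluoro giving a number 84.1 percentage points higher from compound 3 to compound 4 (beyond the scatter) as a large recovery. No measured evidence here explains this gap between hydroxy and fluoro.

Open, from the compounds shown here alone, is whether an amine, a methoxy group or a carboxylic acid on that aromatic carbon tracks hydroxy or fluoro. Also open, going by these compounds, is whether 4-hydroxyphenyl differs from 3-hydroxyphenyl.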